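The compounds below may be only part of what the source reports. "The series", "measured", "known", "first", "only" and "open" are said of these compounds alone.

For the measured compounds named here, compound 2, `O=C(/C=C/c1cn(-c2ccccc2)nc1-c1cccnc1)c1ccccc1`, is one of two compounds measured in a functional assay on MCF7 cells (Homo sapiens) for inhibition, read by sulforhodamine B assay, with a stated time of 72 h; a higher number here means a weaker inhibitor, a lower number a stronger inhibitor; compound 2 gives 4100 nM, and compound 1, `O=C(/C=C/c1cn(-c2ccccc2)nc1-c1cccnc1)c1ccccn1`, gives 4200 nM, the two numbers lying within the scatter of each other. Going by the values given here, the one measured step, a 1.0-fold lower number from compound 1 to compound 2 (0.01 log units; within the scatter), touches the same carbonyl carbon that is changed next. Compound 3, `COc1ccc(OC)c(C(=O)/C=C/c2cn(-c3ccccc3)nc2-c2cccnc2)c1`, differs from compound 2 by 2,5-dimethoxyphenyl in place of phenyl on a carbonyl carbon. Among the compounds with values here, no measured step tells what the two methoxy groups do at this position; the only step at the carbonyl carbon, from pyridin-2-yl to phenyl, stayed within the scatter, so a modest step is expected from compound 2 to compound 3, with no firm direction, and the step of a 1.2-fold lower number from compound 2 to compound 3 (0.07 log units; within the scatter) is the estimate. In this assay compound 3 is therefore expected to give about 3500 nM, with a range from 1000 nM to 12000 nM.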

Compound 3, half-maximal inhibitory concentration: 1500 nM
Beside the measured number, compound 3's estimate is 2.3-fold (0.37 log units) above it; low and high end bracket the measured number.
By their numbers in this assay, from the lowest: compound 3; then compounds 2 and 1 (each within the scatter of the next).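

In this assay the step of a 2.7-fold lower number from compound 2 to compound 3 (0.44 log units; beyond the scatter) and the step of a 2.8-fold lower number from compound 1 to compound 3 (0.45 log units; beyond the scatter) both lie beyond the scatter, though both are modest. For the compounds shown here, the earlier change on this carbonyl carbon, from pyridin-2-yl to phenyl, had stayed within the scatter, so compound 3 is the first sign that the group at this position can move the number, here towards a stronger inhibitor. No evidence is at hand that accounts for this gain.

The compounds shown do not tell whether the step needs both methoxy groups or whether a single methoxy group would do. As far as these compounds go, it also stays open how this position would respond to longer ethoxy groups, a hydroxyl, a dimethylamino group or a carboxylic acid on the phenyl ring.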